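Hydantoin spiro compounds in a seizure model: an N-substituent change

A few compounds are considered here, and "the series" means these few. Any claim that something is new, unique, unknown or untested is made for them only; others in the source may bear on it.

Measured so far:
compound 1 `CC1(C)CC12NC(=O)NC2=O`: 50%
compound 2 `CC(C)N1C(=O)NC2(CC2(C)C)C1=O`: 70%
compound 3 `CCCCN1C(=O)NC2(CC2(C)C)C1=O`: 90%

In a functional assay on the whole organism for inhibition, with Mus musculus as the target, in the maximal electroshock model, at a dose of 30 mg/kg by the oral route (a higher number here means a stronger effect of the compound at the dose given, a lower number a weaker effect), compound 1 gives 50%. Compound 3 stands highest of the three: its nearest neighbour is compound 2, which gives 70%, and the furthest is compound 1. The three steps all concern the group on the amide-type nitrogen in the ring. There was a number 20 percentage points higher from compound 1 to compound 2 (beyond the scatter), a number 40 percentage points higher from compound 1 to compound 3 (beyond the scatter) and a number 20 percentage points higher from compound 2 to compound 3 (beyond the scatter).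

Compound 4 `CCC(CO)N1C(=O)NC2(CC2(C)C)C1=O` has not yet been tested in this assay. The change from compound 3 is 1-(hydroxymethyl)propyl in place of butyl on an amide-type nitrogen in a ring. Among the compounds with values here, of the measured steps, the one from compound 2 to compound 3 bears most directly on it, since both compound 2 and compound 4 carry a branched group where compound 3 carries a straight butyl; there is no measured step that adds a hydroxyl. A modest fall is therefore expected, a number 25 percentage points lower from compound 3 to compound 4 (beyond the scatter), with wide uncertainty. For compound 4 the estimated value is 65%, expected between 40% and 90%.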

Compound 4, a percentage reported as inhibition, in the whole organism at one dose (the size of the read-out at that dose, not a potency): 90%
For compound 4 the middle estimate is 25 percentage points below the measured one; low and high end bracket the measured number.
By their numbers in this assay, from the lowest: compound 1; then compound 2; then compounds 3 and 4 (each within the scatter of the next).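

In this assay the amide-type nitrogen in the ring tolerates a branched group bearing a hydroxyl: with 1-(hydroxymethyl)propyl in place of butyl there is no change at the digits printed from compound 3 to compound 4 (within the scatter) and the added hydrogen-bond donor and acceptor cost nothing visible at this dose. Branching alone therefore does not tie this position to the lower read-out of the isopropyl group, for replacing isopropyl gives a number 20 percentage points higher from compound 2 to compound 4 (beyond the scatter) and replacing hydrogen gives a number 40 percentage points higher from compound 1 to compound 4 (beyond the scatter) in the same assay. Nothing available explains this result.

The compounds shown do not separate the branching from the hydroxyl, which a 1-methylpropyl group would do. On these data alone, it also remains open whether an amine in place of that hydroxyl, or a longer chain than butyl, would keep the read-out at this level.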